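Methylsulfanyl in place of methylsulfonyl: compound 4

This account rests on a few compounds, and the source may have more. Where it says the series, first, only, none or still open, it means among the compounds named here.

Compound 1 `COc1ccc(S(C)(=O)=O)c(NCC2=NCCN2)c1` gives < 100000 nM in a functional assay for agonist activity at Alpha-1D adrenergic receptor (Homo sapiens) (on this read-out lower numbers stand for an effect already at smaller amounts and higher numbers for an effect only at larger amounts of compound), a limit of the assay and not a number.
Compound 2 `CSc1ccc(C)cc1NCC1=NCCN1` gives 0.912 nM in this assay.
Compound 3 `CS(=O)(=O)c1ccc(F)cc1NCC1=NCCN1` gives < 100000 nM in this assay, again a limit and not a number.

Compound 3 thus stands at the limit in this assay, where two of the three values sit (the limit of < 100000 nM in this assay, at which 2 of the 3 values shown sit). Among the measured compounds shown here, the only measured step that touches it, a step that the two limits leave unreadable from compound 1 to compound 3, runs between two limits and its size cannot be read. Compound 4 `CSc1ccc(F)cc1NCC1=NCCN1` carries methylsulfanyl in place of methylsulfonyl on an aromatic carbon. For the measured compounds named here, no measured step contains this change, so its size cannot be taken from the data; the one compound that bears the methylsulfanyl group, compound 2, gives 0.912 nM in this assay. Resting on that value alone, compound 4 is expected to give about 3 nM in this assay, between 0.3 nM and 50 nM, which would mean an estimated step that the limit leaves unreadable from compound 3 to compound 4.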

Compound 4, half-maximal effective concentration: 21.9 nM
For compound 4 the middle estimate is 7.3-fold (0.86 log units) below the measured one, and the stated range covers the measured number.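

In this assay compound 3 gives < 100000 nM, which is a limit of the assay and not a number. With methylsulfanyl in place of methylsulfonyl on the same aromatic carbon, compound 4 gives a measured number, yet the step to it, like the earlier step from the methoxy compound, cannot be read in size: the limit of < 100000 nM in this assay, at which 2 of the 4 values shown sit. Fluoro in place of methyl on an aromatic carbon gives a 24-fold higher number from compound 2 to compound 4 (1.38 log units; beyond the scatter), the first readable step in the series, and shows that with methylsulfanyl in place, the group on that other carbon moves the number well beyond the scatter.

As far as these compounds go, the true size of the change from methylsulfonyl to methylsulfanyl stays open. So does the outcome with a methylsulfinyl group at this position, or with a chloro group or an amine on the carbon that bears the fluoro group.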